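A few compounds are considered here, and "the series" means these few. Any claim that something is new, unique, unknown or untested is made for them only; others in the source may bear on it.

Values in a functional assay on MOLM-13 cells (Homo sapiens) for antiproliferative activity (on this read-out higher numbers stand for weaker inhibition and lower numbers for stronger inhibition), for the measured compounds
Compound 1 `Cc1c(-c2ccc(-c3ccccc3F)cc2)nc2ccc(F)cc2c1C(O)C(F)(F)F` gives 640 nM
Compound 2 `Cc1c(-c2ccc(-c3ccccc3F)cc2)nc2ccc(F)cc2c1C(N)=O` gives 128 nM
Compound 3 `Cc1c(-c2ccc(-c3ccccc3F)cc2)nc2ccc(F)cc2c1C(=O)NC#N` gives > 3000 nM (a limit of the assay, not a number)

Compound 3 stands at a limit and not at a number (the limit of > 3000 nM in this assay, at which 1 of the 3 values shown sits). Compound 4 `CCONC(=O)c1c(C)c(-c2ccc(-c3ccccc3F)cc2)nc2ccc(F)cc12` carries ethoxy in place of cyano on an amide-type nitrogen and is otherwise unchanged. The measured step closest to this change is at that same nitrogen, where an at least 23-fold higher number from compound 2 to compound 3 (1.36 log units; beyond the scatter) is large and came with cyano in place of hydrogen. The other two steps are a 5.0-fold lower number from compound 1 to compound 2 (0.70 log units; beyond the scatter) and an at least 4.6-fold higher number from compound 1 to compound 3 (0.67 log units; beyond the scatter) and they show how widely the group on this carbon can move the number. Within the data shown here, compound 4 loses the cyano, so a move back toward compound 1 is expected, but ethoxy is not hydrogen and no measured compound carries it, so a full return to compound 2 is not expected. The estimated shift for compound 4, a modest one toward lower numbers, is an at least 3.7-fold lower number from compound 3 to compound 4 (0.57 log units; beyond the scatter) in this read-out. In this assay the estimate for compound 4 is 800 nM (expected range 200 nM to 3000 nM).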

Compound 4, half-maximal inhibitory concentration: 33 nM
The estimate for compound 4 lay 24-fold (1.38 log units) above the measured number, outside the stated range (below it).
By their numbers in this assay, from the lowest: compound 4; then compound 2; then compound 1. At a limit, above all of these: compound 3.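

In this assay, among these compounds, the earlier compounds showed only a loss from putting a group on the amide-type nitrogen, whereas ethoxy in place of hydrogen goes the other way, with a 3.9-fold lower number from compound 2 to compound 4 (0.59 log units; beyond the scatter). Ethoxy in place of cyano gives an at least 90-fold lower number from compound 3 to compound 4 (1.95 log units; beyond the scatter), so the two groups at this nitrogen fall on opposite sides of the unsubstituted amide, though this step starts from a limit of the assay and not a number: the limit of > 3000 nM in this assay, at which 1 of the 4 values shown sits. Ethoxycarbamoyl in place of 2,2,2-trifluoro-1-hydroxyethyl on the aromatic carbon gives a 19-fold lower number from compound 1 to compound 4 (1.29 log units; beyond the scatter), a larger step than the carbamoyl group gave.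

The compounds shown leave open whether this trend is specific to ethoxy. Methoxy, hydroxy, a longer alkoxy chain or a plain ethyl group on the same nitrogen could each answer that.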